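A Cyclopropylamino Variant of a Hydrolase Inhibitor

The source may report more compounds than this note shows. Statements on the series, on what has been measured and on what is new or still open speak of the compounds shown alone.

Compound 1 `CN(C)Cc1ccc(-c2c3ncn(CC4(O)CCN(Cc5ccc(-c6ccco6)cc5Cl)CC4)c(=O)c3nn2C)cc1` is the weaker of the two measured compounds: in an assay on isolated protein for inhibition of ubiquitin carboxyl-terminal hydrolase 7 (Homo sapiens), with stated times of 30 min and 2 h (on this read-out higher numbers stand for weaker inhibition and lower numbers for stronger inhibition), compound 1 gives 131 nM, whereas compound 2 `Cn1nc2c(=O)n(CC3(O)CCN(Cc4ccc(-c5ccsc5)cc4Cl)CC3)cnc2c1-c1ccc(CN)cc1` gives 59.5 nM, a lower number beyond the usual scatter. Compound 3 `Cn1nc2c(=O)n(CC3(O)CCN(Cc4ccc(-c5ccco5)cc4Cl)CC3)cnc2c1-c1ccc(CNC2CC2)cc1` differs from compound 1 by one change (cyclopropylamino in place of dimethylamino on a saturated chain carbon bound to an aromatic carbon). Among the measured compounds shown here, no single-change step between measured compounds exists here, so the size of this step is uncertain; a small drop or no change beyond the scatter is expected, by analogy with the lower number of compound 2 at 59.5 nM. Compound 3 is therefore estimated at 90 nM, within 35 nM to 250 nM, a step of a 1.5-fold lower number from compound 1 to compound 3 (0.16 log units; within the scatter).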

Compound 3, half-maximal inhibitory concentration: 54.1 nM
Estimate against measurement, compound 3: 1.7-fold (0.22 log units) above; measured number inside the range.
By their numbers in this assay, from the lowest: compounds 3 and 2 (each within the scatter of the next); then compound 1.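

In this assay, this place, a saturated chain carbon bound to an aromatic carbon, now has a step of its own: cyclopropylamino in place of dimethylamino gives a 2.4-fold lower number from compound 1 to compound 3 (0.38 log units; beyond the scatter) and thus a modest change beyond the scatter. The amino group here therefore affects the read-out, and the swap brings in a hydrogen-bond donor and a three-membered ring together. Nothing measured here gives a reason for the step.

From the compounds shown here alone, whether the step goes with the donor or with the ring remains open. Methylamino, with the donor and no ring, and N-cyclopropyl-N-methylamino, with the ring and no donor, would separate the two.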